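Fluoro to hydrogen on the aryl ring of compound 2

The source may report more compounds than this note shows. Statements on the series, on what has been measured and on what is new or still open speak of the compounds shown alone.

Working notes on the series. Compound 1 `C[C@@H]1C=NN(C(=O)C(C)(C)C)[C@@H]1c1ccccc1` and compound 2 `Cc1ccc(C2CC=NN2C(=O)C(C)(C)C)cc1F` share a core and carry different aryl substitution. In an ADME assay on microsomes (Rattus norvegicus) for metabolic stability (a lower number here means that the compound disappears faster, a higher number that the compound lasts longer), compound 1 gives 0.2 h. In this assay, for the measured compounds named here, compound 2 gives 0.0433 h, the lowest of the two numbers measured so far; compound 1 sits above it by a gap beyond the scatter. Going by the values given here, no pair of measured compounds differs in a single place, so this gap cannot be tied to one part of the structure. Compound 3 `Cc1ccc(C2CC=NN2C(=O)C(C)(C)C)cc1` differs from compound 2 in one place: hydrogen in place of fluoro on an aromatic carbon. Among the compounds with values here, for this change no measured pair exists. The expected step is a 1.2-fold lower number from compound 2 to compound 3 (0.09 log units; within the scatter), small, downward if at all, and probably within the scatter. Compound 3 is therefore estimated at 0.035 h in this assay, with a range from 0.015 h to 0.09 h.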

Compound 3, half-life: 0.0383 h
For compound 3 the middle estimate is 1.1-fold (0.04 log units) below the measured one, and the stated range covers the measured number.
By their numbers in this assay, from the lowest: compounds 3 and 2 (each within the scatter of the next); then compound 1.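

Hydrogen in place of fluoro on an aromatic carbon, ortho to a methyl group, gives a 1.1-fold lower number from compound 2 to compound 3 (0.05 log units; within the scatter) in this assay. This is the only single-place step among the compounds shown, and at this position it does not separate the two compounds beyond the scatter. No other data bear on the reason for this result.

As far as these compounds go, whether a chlorine atom, a methoxy group or an amine at this position would move the number beyond the scatter stays open. Also open, from the compounds shown here alone, are whether the same exchange reads alike at other carbons of the aromatic ring or on the core of compound 1, and what a trifluoromethyl group in place of the methyl group would do.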